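Bromo substitution on the fused bicyclic ring of compound 2

This account rests on a few compounds, and the source may have more. Where it says the series, first, only, none or still open, it means among the compounds named here.

Two compounds of the series have numbers in a functional assay on cells (Cancer cell lines, Homo sapiens) for cytotoxicity, read by sulforhodamine B assay, with a stated time of 48 h; on this read-out higher numbers stand for weaker inhibition of growth and lower numbers for stronger inhibition of growth. Compound 1 `COc1ccc(C2CC(c3ccccc3)=NN2C2=NC(=O)/C(=C3\C(=O)Nc4ccc(Br)cc43)S2)cc1` gives 230 nM in this assay. Compound 2 `COc1ccc(C2CC(c3ccc4ccccc4c3)=NN2C2=NC(=O)/C(=C3\C(=O)Nc4ccccc43)S2)cc1` gives 970 nM, the highest of the two numbers, and the gap to compound 1 lies beyond the scatter. Compound 3 `COc1ccc(C2CC(c3ccc4ccccc4c3)=NN2C2=NC(=O)/C(=C3\C(=O)Nc4ccc(Br)cc43)S2)cc1` carries bromo in place of hydrogen on an aromatic carbon, on an aromatic carbon of a six-membered aromatic ring of carbon only within a fused system of two rings. Within the data shown here, no single-change step is known for this change, so compound 3 is expected to show a modest lowering, a 1.9-fold lower number from compound 2 to compound 3 (0.29 log units; within the scatter), only just beyond the scatter, because compound 1, which also carries bromo there, gives 230 nM. Compound 3 is estimated at 500 nM, between 200 nM and 1500 nM.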

Compound 3, concentration for 50% growth inhibition: 110 nM
For compound 3 the middle estimate is 4.5-fold (0.66 log units) above the measured one; the measured number lies below the stated range.
By their numbers in this assay, from the lowest: compound 3; then compound 1; then compound 2.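

Bromo in place of hydrogen on this aromatic carbon now has a step of its own in this assay: an 8.8-fold lower number from compound 2 to compound 3 (0.95 log units; beyond the scatter). With bromo kept in place, naphthalen-2-yl in place of phenyl on the carbon with a double bond to nitrogen also lowers the number, giving a 2.1-fold lower number from compound 1 to compound 3 (0.32 log units; beyond the scatter). Nothing on hand accounts for either step. The compounds shown leave open how chloro, methoxy or an amine on this aromatic carbon would compare with bromo. Also open, on these data alone, is whether the bromo step holds with phenyl in place of naphthalen-2-yl.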